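This account rests on a few compounds, and the source may have more. Where it says the series, first, only, none or still open, it means among the compounds named here.

Compound 1 `CC(=O)Nc1n[nH]c2cc(-c3cn([C@@H]4CN[C@H](C(=O)Nc5ccc(Cl)c(C(F)(F)F)c5)C4)nn3)ccc12` and compound 2 `O=C(Nc1n[nH]c2cc(-c3cn([C@@H]4CN[C@H](C(=O)Nc5ccc(Cl)c(C(F)(F)F)c5)C4)nn3)ccc12)C1CC1` share one core, and in a functional assay on K562 cells (Homo sapiens) for inhibition, read by MTT assay, with a stated time of 48 h (a higher number here means a weaker inhibitor, a lower number a stronger inhibitor), compound 1 gives 15500 nM while compound 2 gives 5200 nM. The change between them, (cyclopropyl in place of methyl on a carbonyl carbon), brought a 3.0-fold lower number from compound 1 to compound 2 (0.47 log units; beyond the scatter). Compound 3 `CC(=O)Nc1nc2ccc(-c3cn([C@@H]4CN[C@H](C(=O)Nc5ccc(F)c(F)c5)C4)nn3)nc2s1` rests on a different core; the difference between the two cores is not broken down here. In this assay compound 3 gives 63000 nM, the highest of the three numbers. Compound 4 `O=C(Nc1nc2ccc(-c3cn([C@@H]4CN[C@H](C(=O)Nc5ccc(F)c(F)c5)C4)nn3)nc2s1)C1CC1` has not yet been measured and differs from compound 3 by cyclopropyl in place of methyl on a carbonyl carbon, the same change at the same place as that from compound 1 to compound 2. On the strength of that earlier step from compound 1 to compound 2, a 3.0-fold lower number from compound 1 to compound 2 (0.47 log units; beyond the scatter), a step of a 3.0-fold lower number from compound 3 to compound 4 (0.48 log units; beyond the scatter) is expected in this assay. Compound 4 is therefore estimated at 21000 nM, within 8000 nM to 50000 nM.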

Compound 4, half-maximal inhibitory concentration: 40700 nM
Compound 4: middle estimate off by 1.9-fold (0.29 log units), on the low side, within the range that was stated.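

In this assay, cyclopropyl in place of methyl on a carbonyl carbon brought a 1.5-fold lower number from compound 3 to compound 4 (0.19 log units; within the scatter), a step that cannot be told from the usual scatter on its own. Set beside the earlier step, the two results do not separate: the same change on two cores in this assay, a 3.0-fold lower number (0.47 log units; beyond the scatter) from compound 1 to compound 2 and a 1.5-fold lower number (0.19 log units; within the scatter) from compound 3 to compound 4, 1.9-fold (0.28 log units) apart, within the scatter of two such steps. This shows that the step on one core is compatible with that on the other, but two pairs do not establish a fixed size for the change, nor show that it would hold on a further core.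

As far as these compounds go, whether ethyl, a longer chain or an amine on that carbonyl carbon would behave alike remains open. From the compounds shown here alone, the two pairs also differ in more than the core, so the contribution of the core alone remains open too.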